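The source may report more compounds than this note shows. Statements on the series, on what has been measured and on what is new or still open speak of the compounds shown alone.

Measured compounds:
compound 1, `Cc1ccc(NC(=O)N[C@H](C)c2ccccc2)cc1`, 100%
compound 2, `Cc1ccc(NC(=O)N[C@@H](C)c2ccccc2)cc1`, 100%

In an ADME assay on the whole organism with Oryza sativa as the target, tested at 0.1 uM (a lower number here means a stronger effect, a higher number a weaker effect of the compound at the concentration tested), compound 1 gives 100%. Compound 2 gives 100% in this assay, so the step of no change at the digits printed from compound 1 to compound 2 (within the scatter) lies within the scatter, which fits with the fact that compounds 1 and 2 differ only in the configuration as drawn. Compound 1 therefore stands level with compound 2, with nothing in the measured pair to separate them.

Compound 3, `CCCCCc1ccc(NC(=O)N[C@H](C)c2ccccc2)cc1`, has not yet been measured. Compared with compound 1 the change is butyl in place of hydrogen on a saturated chain carbon bound to an aromatic carbon. Within the data shown here, no measured step bears on this change: the one step on record alters only configuration, not the chain on the saturated carbon. With the two measured values sitting at the same level, there is no ground to expect a step beyond the scatter in this assay. Compound 3 is therefore estimated at 97%, within a range of 80% to 105%. The expected step of a number 3 percentage points lower from compound 1 to compound 3 (within the scatter) is small.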

Compound 3, a percentage reported as activity, at one concentration (the size of the read-out at that concentration, not a potency): 100%
The estimate for compound 3 lay 3 percentage points below the measured number; the range from low to high includes it.
By their numbers in this assay, from the lowest: compounds 1, 2 and 3 (each within the scatter of the next).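

In this assay, butyl in place of hydrogen on a saturated chain carbon bound to an aromatic carbon gives no change at the digits printed from compound 1 to compound 3 (within the scatter). The earlier pair spoke only to configuration, whereas this result concerns the group itself: the same difference, read as methyl to pentyl, brings no stronger effect at the concentration tested, and compound 3 gives 100%. Nothing on record accounts for this outcome.

The compounds shown leave open whether any group at this place can lower the number, for example an amine, a carboxylic acid or a chain longer than pentyl. Among these compounds, they also leave open whether the configuration of the stereocentre would matter with pentyl present, since the one step on configuration was read with methyl in that place.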